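Thiourea series on THP-1 viability: tert-butyl to methyl

This account rests on a few compounds, and the source may have more. Where it says the series, first, only, none or still open, it means among the compounds named here.

Measured so far in a functional assay on THP-1 cells (Homo sapiens) for cytotoxicity, read by MTT assay, with a stated time of 24 h; on this read-out higher numbers stand for weaker inhibition and lower numbers for stronger inhibition:
- compound 1, `Clc1cccc(-c2nnc(SCCCN3CCN(c4ncccn4)CC3)[nH]2)c1`: > 300000 nM, a limit of the assay, not a number
- compound 2, `CC(C)(C)c1ccc(-c2nn(CCCN3CCN(c4ccccc4)CC3)c(=S)[nH]2)cc1`: 147000 nM
- compound 3, `CC(C)(C)c1ccc(-c2nn(CCCN3CCN(c4cccc(Cl)c4)CC3)c(=S)[nH]2)cc1`: > 300000 nM, a limit of the assay, not a number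

Compound 3 therefore stands only at a limit in this assay, and it shares that position with one other entry, as the limit of > 300000 nM in this assay, at which 2 of the 3 values shown sit, records. Going by the values given here, the single measured step that leads into compound 3 is an at least 2.0-fold higher number from compound 2 to compound 3 (0.30 log units; that floor lies within the scatter), a chloro in place of hydrogen on an aromatic carbon, and its floor does not exceed the usual scatter.

Compound 4, `Cc1ccc(-c2nn(CCCN3CCN(c4cccc(Cl)c4)CC3)c(=S)[nH]2)cc1`, differs from compound 3 by methyl in place of tert-butyl on an aromatic carbon. Among the compounds with values here, no measured pair shows this particular exchange, so nothing among the steps above bears directly on it; the only guidance is that both entries carrying the chloro-substituted piperazine sit at the limit. The expectation is therefore no movement beyond the scatter in this assay, with the expected step being a number no higher from compound 3 to compound 4 (the limit leaves the size open). For compound 4 the estimate is 300000 nM, within 120000 nM to 700000 nM, and it is expected that the assay may again return only a limit.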

Compound 4, half-maximal inhibitory concentration: > 300000 nM
Compound 4 was reported as a limit; the forecaster's own chance of this, stated with the estimate: 60%; the middle value lies on the limit itself.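

Compound 3 and compound 4 both stand only at a limit of the assay in this assay, so no step can be read from compound 3 to compound 4: the limit of > 300000 nM in this assay, at which 3 of the 4 values shown sit.

The compounds shown leave open whether methyl in place of tert-butyl changes the read-out at all in this assay.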